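The compounds below may be only part of what the source reports. "The series", "measured", "known", "first", "only" and "open" are said of these compounds alone.

Compound 1 `Cc1ccc(NC(=O)c2cccc(C(F)(F)F)c2)cc1N1Cc2cnc(Nc3ccc(C)c(C(F)(F)F)c3)nc2N(C)C1=O` gives 29 nM in a functional assay on K562 cells (Homo sapiens) for antiproliferative activity, read by CellTiter-Glo and CCK-8 assay, with a stated time of 72 h; on this read-out lower numbers stand for stronger inhibition of growth and higher numbers for weaker inhibition of growth. Of the three measured compounds it stands second highest: compound 2 `Cc1cc(C)cc(C(=O)Nc2ccc(C)c(N3Cc4cnc(Nc5ccc(C)c(N)c5)nc4N(C)C3=O)c2)c1` gives 26 nM, within the scatter of compound 1, while compound 3 `Cc1cccc(C(=O)Nc2ccc(C)c(N3Cc4cnc(Nc5ccc(C)c(N)c5)nc4N(C)C3=O)c2)c1` gives 68.8 nM. The only step shown, a 2.6-fold higher number from compound 2 to compound 3 (0.42 log units; beyond the scatter), concerns a methyl on an aromatic carbon in another part of the molecule and does not bear on the change to compound 4 `Cc1ccc(NC(=O)c2cccc(C(F)(F)F)c2)cc1N1Cc2cnc(O[C@H]3CCNC3)nc2N(C)C1=O`, which is (pyrrolidin-3-yl)oxy in place of (4-methyl-3-(trifluoromethyl)phenyl)amino on an aromatic carbon. For the measured compounds named here, no measured step covers an exchange of this kind, so the expectation is uncertain. For compound 4 a step of a 14-fold higher number from compound 1 to compound 4 (1.14 log units; beyond the scatter) toward a higher number in this assay is expected. The estimate for compound 4 is 400 nM, with a range of 50 nM to 4000 nM.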

Compound 4, concentration for 50% growth inhibition: 450 nM
Beside the measured number, compound 4's estimate is 1.1-fold (0.05 log units) below it; low and high end bracket the measured number.
By their numbers in this assay, from the lowest: compounds 2 and 1 (each within the scatter of the next); then compound 3; then compound 4.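

For the compounds shown here, at the aromatic carbon between two ring nitrogen atoms, the earlier compounds carried only substituted phenylamino groups. Replacing (4-methyl-3-(trifluoromethyl)phenyl)amino with (pyrrolidin-3-yl)oxy gives a 16-fold higher number from compound 1 to compound 4 (1.19 log units; beyond the scatter) in this assay, so this position accepts a non-aromatic ring joined through oxygen, but at a large cost in growth inhibition. Nothing available explains the size of this step.

As far as these compounds go, it remains open whether the step follows from the oxygen link, the loss of the aromatic ring or the pyrrolidine itself. A (pyrrolidin-3-yl)amino group or an unsubstituted phenylamino group at this position would help separate these.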